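Lengthening the Chain of a Compound at the Limit

The source may report more compounds than this note shows. Statements on the series, on what has been measured and on what is new or still open speak of the compounds shown alone.

In a functional assay on HCT-116 cells (Homo sapiens) for antiproliferative activity, read by MTT assay, with a stated time of 48 h (on this read-out higher numbers stand for weaker inhibition and lower numbers for stronger inhibition), compound 1 (`CCCCCCCC(CCO)n1cnc2c(NC)ncnc21`) gives 12500 nM. Compound 2 (`CCCCCCCC(CCO)n1cnc2c(N)ncnc21`) has only a limit, > 50000 nM, and no exact number. Compound 3 (`CCCCCCCC(CCO)n1cnc2c(N)nc(Cl)nc21`) also has only a limit, > 50000 nM. Compound 2 therefore stands at the limit of > 50000 nM in this assay, at which 2 of the 3 values shown sit.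

Compound 4 (`CCCCCCCCCCCC(CCO)n1cnc2c(N)ncnc21`) differs from compound 2 by butyl in place of hydrogen on a saturated chain carbon, eight bonds along the chain from an aromatic nitrogen. Two measured steps are nearby: an at least 4.0-fold higher number from compound 1 to compound 2 (0.60 log units; beyond the scatter), and a step that the two limits leave unreadable from compound 2 to compound 3. Neither changes the chain, so they offer only weak guidance, and compound 4 may stay at the limit.

The expected change is modest, toward stronger inhibition: an at least 2.2-fold lower number from compound 2 to compound 4 (0.35 log units; beyond the scatter). For compound 4, the estimate is 22000 nM, with an expected range of 7000 nM to 50000 nM.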

Compound 4, half-maximal inhibitory concentration: 13400 nM
The estimate for compound 4 lay 1.6-fold (0.22 log units) above the measured number, and the stated range covers the measured number.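

In this assay, within the data shown here, the earlier steps changed only groups on the shared core, so this is the first reading of the chain itself: butyl in place of hydrogen gives an at least 3.7-fold lower number from compound 2 to compound 4 (0.57 log units; beyond the scatter). The chain position therefore responds to change, and this lengthening alone brings the compound off the limit to a measurable value. The true size of the step stays unknown, since compound 2 has only a limit: the limit of > 50000 nM in this assay, at which 2 of the 4 values shown sit.

As far as these compounds go, whether a longer chain, such as octyl in place of butyl, would strengthen inhibition further remains open. So does whether butyl and the methyl on the nitrogen of compound 1 would add together.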